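Series notes: from compound 1 to compound 4

A few compounds are considered here, and "the series" means these few. Any claim that something is new, unique, unknown or untested is made for them only; others in the source may bear on it.

Compound 1 `CN(C)CC(=O)N1CCC(NS(=O)(=O)c2cc(S(=O)(=O)c3ccccc3)ccc2C(F)(F)F)CC1` gives 280 nM in a functional assay on U2OS cells for antagonist activity at proto-oncogene Wnt-3 (Homo sapiens), read by a luciferase reporter, with a stated time of 18 h (on this read-out lower numbers stand for an effect already at smaller amounts and higher numbers for an effect only at larger amounts of compound), the highest of the three numbers in hand. Compound 2 `O=C(CN1CCNCC1)N1CCC(NS(=O)(=O)c2cc(S(=O)(=O)c3ccccc3)ccc2C(F)(F)F)CC1` gives 250 nM in this assay; the step of a 1.1-fold lower number from compound 1 to compound 2 (0.05 log units; within the scatter) is within the scatter, so the two are not told apart. Compound 3 `CC(C)(C)NC(=O)N1CCC[C@H]1C(=O)N1CCC(NS(=O)(=O)c2cc(S(=O)(=O)c3ccccc3)ccc2C(F)(F)F)CC1` gives 30 nM in this assay, and the steps of a 9.3-fold lower number from compound 1 to compound 3 (0.97 log units; beyond the scatter) and an 8.3-fold lower number from compound 2 to compound 3 (0.92 log units; beyond the scatter) are both beyond the scatter.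

Compound 4 `CC(C)(C)CCN1CCC[C@H]1C(=O)N1CCC(NS(=O)(=O)c2cc(S(=O)(=O)c3ccccc3)ccc2C(F)(F)F)CC1` has not yet been measured in this assay. Its difference from compound 1 is 1-(3,3-dimethylbutyl)pyrrolidin-2-yl in place of (dimethylamino)methyl on a carbonyl carbon. For the measured compounds named here, the steps to compound 3 bear on this change, since compound 3 and compound 4 both carry a pyrrolidin-2-yl on the carbonyl carbon; what sits on the ring nitrogen differs, 1-((tert-butyl)carbamoyl) in compound 3 against 3,3-dimethylbutyl in compound 4, and no measured pair isolates that exchange. The expectation therefore leans on compound 3 with 30 nM but with a wider range, and a lowering is expected, a 4.7-fold lower number from compound 1 to compound 4 (0.67 log units; beyond the scatter). Compound 4 is estimated at 60 nM in this assay, within a range of 20 nM to 200 nM.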

Compound 4, half-maximal effective concentration: 450 nM
The estimate for compound 4 lay 7.5-fold (0.88 log units) below the measured number; measured number above the stated range.
By their numbers in this assay, from the lowest: compound 3; then compounds 2, 1 and 4 (each within the scatter of the next).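

In this assay, the pyrrolidin-2-yl on the carbonyl carbon does not by itself bring the lower number seen with compound 3: the only pair shown that isolates the group on the ring nitrogen gives the large step (a 15-fold higher number from compound 3 to compound 4 (1.18 log units; beyond the scatter)) when 3,3-dimethylbutyl replaces (tert-butyl)carbamoyl. The other two steps (a 1.6-fold higher number from compound 1 to compound 4 (0.21 log units; within the scatter); a 1.8-fold higher number from compound 2 to compound 4 (0.26 log units; within the scatter)) lie within the scatter, so the 1-(3,3-dimethylbutyl)pyrrolidin-2-yl group, with its 11 heavy atoms and five-membered ring, is not told apart from the (dimethylamino)methyl or (piperazin-1-yl)methyl groups it replaces. Among the compounds shown, the separation therefore tracks the (tert-butyl)carbamoyl group on the ring nitrogen, but no supporting data are available to explain this difference.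

Still open, going by these compounds, is how an acetyl group, a methyl carbamate or the smaller methylcarbamoyl group on the ring nitrogen would compare with the (tert-butyl)carbamoyl group of compound 3 (30 nM). Also open, on these data alone, is what the free secondary amine of the unsubstituted pyrrolidin-2-yl would give on the same carbonyl carbon in this assay on this read-out.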